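The source may report more compounds than this note shows. Statements on the series, on what has been measured and on what is new or still open speak of the compounds shown alone.

Measured so far in a toxicity assay on cells (Macrophage, Mus musculus, strain BALB/c) for cytotoxicity, read by MTT assay; on this read-out lower numbers stand for stronger inhibition and higher numbers for weaker inhibition:
compound 1, `C=CCOc1cc(OC)c(C(=O)/C=C/c2ccc([N+](=O)[O-])cc2)c(OCC=C)c1`: 13200 nM
compound 2, `COc1cc(O)cc(O)c1C(=O)/C=C/c1ccc(O)cc1`: 21700 nM

Compound 1 stands at the lowest of the two numbers shown; its nearest is compound 2, and that gap lies within the scatter of the method, so the two are not told apart. Compound 3, `C=CCOc1cc(OC)c(C(=O)/C=C/c2ccccn2)c(OCC=C)c1`, is not yet measured in this assay. It differs from compound 1 by pyridin-2-yl in place of 4-nitrophenyl on a double-bonded chain carbon bound to a double-bonded chain carbon. Within the data shown here, no step between measured compounds covers this change, so the expectation rests on compound 1 alone. A step of a 1.1-fold higher number from compound 1 to compound 3 (0.06 log units; within the scatter) is expected, not beyond the scatter. Compound 3 is estimated at 15000 nM, within 5000 nM to 45000 nM.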

Compound 3, half-maximal inhibitory concentration: 12500 nM
The estimate for compound 3 lay 1.2-fold (0.08 log units) above the measured number; the measured number falls inside the stated range.
By their numbers in this assay, from the lowest: compounds 3, 1 and 2 (each within the scatter of the next).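

In this assay, pyridin-2-yl in place of 4-nitrophenyl on a double-bonded chain carbon bound to a double-bonded chain carbon gives a 1.1-fold lower number from compound 1 to compound 3 (0.02 log units; within the scatter) and leaves the two compounds indistinguishable. At this place, a ring with one hetero atom and no nitro group therefore reads the same as the 4-nitrophenyl ring. No evidence on the reason for this is at hand.

On these data alone, whether a plain phenyl group would also read the same remains open. So does whether an amine or a carboxylic acid on this ring would give a step beyond the scatter.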